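Trimming the Aryl Group on a Low-Toxicity Hydrazone

The source may hold more compounds than are shown below. What is called first, only, known or untested is meant among the compounds shown, and "the series" means these compounds.

Compound 2 `COc1cc(/C=N/NC(=O)CSc2nnnn2-c2cccc3ccccc23)ccc1O` was measured in an ADME assay on MT4 cells (Homo sapiens) for cytotoxicity, read by MTT assay; on this read-out higher numbers stand for lower toxicity in this test and lower numbers for higher toxicity in this test. Compound 2 reaches only a limit there, > 287000 nM. Compound 1 `COc1cccc(/C=N/NC(=O)CSc2nnnn2-c2cccc3ccccc23)c1OC` gives 192000 nM in this assay. The step of an at least 1.4-fold higher number from compound 1 to compound 2 (0.17 log units; that floor lies within the scatter) stays within the scatter, and one value sits at the limit of > 287000 nM in this assay, at which 1 of the 2 values shown sits. Compound 3 `O=C(CSc1nnnn1-c1cccc2ccccc12)N/N=C/c1cccc(O)c1` is not yet measured; the change is 3-hydroxyphenyl in place of 4-hydroxy-3-methoxyphenyl on a carbon with a double bond to nitrogen. Going by the values given here, only the step from compound 1 to compound 2 bears on this move, and since it stayed within the scatter, no step beyond the scatter is expected in this assay. Compound 3 is therefore expected near 260000 nM, between 120000 nM and 600000 nM. This amounts to an expected at least 1.1-fold lower number from compound 2 to compound 3 (0.04 log units; that floor lies within the scatter).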

Compound 3, half-maximal cytotoxic concentration: 169000 nM
Compound 3: middle estimate off by 1.5-fold (0.19 log units), on the high side, and the stated range covers the measured number.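

Replacing 2,3-dimethoxyphenyl with 3-hydroxyphenyl on this carbon gives, in this assay, a 1.1-fold lower number from compound 1 to compound 3 (0.06 log units; within the scatter), so a single hydroxyl in place of two methoxy groups leaves the number within the scatter. Replacing 4-hydroxy-3-methoxyphenyl with 3-hydroxyphenyl gives an at least 1.6-fold lower number from compound 2 to compound 3 (0.22 log units; that floor lies within the scatter). Compound 2 holds only a limit, not a number, so the full size of that step cannot be read: the limit of > 287000 nM in this assay, at which 1 of the 3 values shown sits.

Still open, as far as these compounds go, is how this position would respond to an aryl group bearing an amine or a carboxylic acid, and whether any such group would move the number beyond the scatter.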